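Replacing the indazole of compound 2 with a new bicyclic group

This account rests on a few compounds, and the source may have more. Where it says the series, first, only, none or still open, it means among the compounds named here.

Measured so far:
compound 1 `O=C(Nc1cccc2nonc12)N1CCN(Cc2cccc(Oc3ccc(Cl)cc3)c2)CC1`: 120 nM
compound 2 `O=C(Nc1cccc2cn[nH]c12)N1CCN(Cc2cccc(Oc3ccc(Cl)cc3)c2)CC1`: 6000 nM
compound 3 `Cc1nc2cc(NC(=O)N3CCN(Cc4cccc(Oc5ccc(Cl)cc5)c4)CC3)ccc2o1`: 200 nM

All three were tested in an assay on isolated protein for inhibition of Fatty-acid amide hydrolase 1 (Rattus norvegicus), with a stated time of 60 min; a lower number here means a stronger inhibitor, a higher number a weaker inhibitor. Compound 2 gives the highest number of the three; the step of a 30-fold lower number from compound 2 to compound 3 (1.48 log units; beyond the scatter) and the step of a 50-fold higher number from compound 1 to compound 2 (1.70 log units; beyond the scatter) are both large. Compound 4 `O=C(Nc1noc2ccncc12)N1CCN(Cc2cccc(Oc3ccc(Cl)cc3)c2)CC1` is not yet measured. It differs from compound 2 in one place: a group of 9 heavy atoms (6 carbon, 2 nitrogen, 1 oxygen; one five-membered aromatic ring with 2 hetero atoms, one six-membered aromatic ring with 1 hetero atom) in place of a group of 9 heavy atoms (7 carbon, 2 nitrogen; one five-membered aromatic ring with 2 hetero atoms, one six-membered aromatic ring of carbon only), on an amide-type nitrogen. Both measured steps replaced or introduced the indazole group of compound 2 and were large, and the change to compound 4 again removes that group, so a large drop in number is expected, roughly a 24-fold lower number from compound 2 to compound 4 (1.38 log units; beyond the scatter). Compound 4 is therefore estimated at 250 nM, with a range from 60 nM to 1000 nM.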

Compound 4, half-maximal inhibitory concentration: 2200 nM
The estimate for compound 4 lay 8.8-fold (0.94 log units) below the measured number, outside the stated range (above it).
By their numbers in this assay, from the lowest: compounds 1 and 3 (each within the scatter of the next); then compound 4; then compound 2.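

In this assay, removing the indazole is not enough by itself: the change gives only a 2.7-fold lower number from compound 2 to compound 4 (0.44 log units; beyond the scatter), yet still leaves an 11-fold higher number from compound 3 to compound 4 (1.04 log units; beyond the scatter). The group of compound 4 has the same heavy-atom count as the group of compound 1, with its hetero atoms spread differently over the two rings, but the step is large: an 18-fold higher number from compound 1 to compound 4 (1.26 log units; beyond the scatter). No measured evidence explains this gap. From the compounds shown here alone, it remains open whether the nitrogen of the six-membered ring matters, which a carbon-only version of this group could test. A plain phenyl on the amide-type nitrogen could show whether the second ring is needed.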